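Swapping the Halogen on the Benzyl Group of Compound 2

The source may report more compounds than this note shows. Statements on the series, on what has been measured and on what is new or still open speak of the compounds shown alone.

Compound 2, with the structure `Clc1cccc(Cn2cc(COc3ccccc3)nn2)c1`, was tested in an ADME assay on A549 cells (Homo sapiens) for inhibition, read by MTT assay, with a stated time of 48 h; a higher number here means a weaker inhibitor of growth, a lower number a stronger inhibitor of growth. In this assay compound 2 gives > 100 ug/mL, which is a limit of the assay rather than a measured number. Its close relative compound 1, `Clc1ccc(Cn2cc(COc3ccccc3)nn2)cc1`, carries 4-chlorophenyl where compound 2 carries 3-chlorophenyl. In this assay compound 1 gives > 100 ug/mL, again a limit. The step from compound 1 to compound 2 is therefore a step that the two limits leave unreadable from compound 1 to compound 2. Both results sit at the limit of > 100 ug/mL in this assay, at which 2 of the 2 values shown sit. Compound 3, `Brc1ccc(Cn2cc(COc3ccccc3)nn2)cc1`, carries the change (4-bromophenyl in place of 3-chlorophenyl on a saturated chain carbon bound to an aromatic nitrogen). Within the data shown here, the one measured step bears on it only in that both of its ends stop at the same limit, so no size can be read from it. The step from compound 2 to compound 3 is expected to be a step that the limit leaves unreadable from compound 2 to compound 3, in effect no readable change. Compound 3 is estimated at 150 ug/mL, within a range from 60 ug/mL to 400 ug/mL, and is most likely reported again only as a limit.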

Compound 3, concentration for 50% growth inhibition: > 100 ug/mL
Compound 3 ended at the assay's limit; the forecaster's own chance of this, stated with the estimate: 85%; the middle value is on the limit's open side.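

No step among compound 1, compound 2 and compound 3 can be read, since all three stop at the same limit: the limit of > 100 ug/mL in this assay, at which 3 of the 3 values shown sit.

The compounds shown leave open how strongly each one inhibits growth, and whether 4-chlorophenyl, 3-chlorophenyl and 4-bromophenyl differ at all.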